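A Hydroxy Added to Compound 2

The compounds below may be only part of what the source reports. "The series", "measured", "known", "first", "only" and "open" are said of these compounds alone.

In an ADME assay on CNE-2 cells (Homo sapiens) for cytotoxicity, read by MTT assay, with a stated time of 48 h (on this read-out higher numbers stand for weaker inhibition and lower numbers for stronger inhibition), compound 1 `COc1ccc(-c2cn(Cc3ccc(C(C)(C)C)cc3)nn2)cc1` gives 4000 nM and compound 2 `CC(C)(C)c1ccc(Cn2cc(-c3ccc(O)cc3)nn2)cc1` gives 5600 nM, so these two values lie within the scatter of each other. Compound 3 `CC(C)(C)c1ccc(Cn2cc(-c3ccc(O)cc3)nn2)c(O)c1` differs from compound 2 by hydroxy in place of hydrogen on an aromatic carbon, ortho to a large group. Going by the values given here, the only measured step, a 1.4-fold higher number from compound 1 to compound 2 (0.15 log units; within the scatter), replaced methyl on an oxygen, so it offers limited guidance, and no change beyond the scatter is expected in this assay. The expected step is a 1.1-fold lower number from compound 2 to compound 3 (0.05 log units; within the scatter). Compound 3 is estimated at 5000 nM, with an expected range from 1800 nM to 14000 nM.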

Compound 3, half-maximal inhibitory concentration: > 20000 nM
Compound 3 was reported as a limit; the forecaster's own chance of this, stated with the estimate: 5%; middle value at least 4.0-fold (0.60 log units) from the limit.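

The earlier step only swapped a methyl on an oxygen and stayed within the scatter, whereas a change at this aromatic carbon, ortho to a large group and meta to a tert-butyl group, gives an at least 3.5-fold higher number from compound 2 to compound 3 (0.55 log units; beyond the scatter). In this assay, adding hydroxy at this position therefore weakens inhibition. The value of compound 3 is a limit, not a number: the limit of > 20000 nM in this assay, at which 1 of the 3 values shown sits.

The compounds shown leave open whether an amine or a fluorine atom on this same carbon would also weaken inhibition, or whether the loss belongs to hydroxy alone.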